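A few compounds are considered here, and "the series" means these few. Any claim that something is new, unique, unknown or untested is made for them only; others in the source may bear on it.

Measured compounds and their results:
Compound 1 `Cc1nc(-c2ccc(Cl)cc2)sc1C1SCC(=O)N1c1ccc(F)c(Cl)c1` gives 65.1% in a functional assay on the whole organism (strain Wistar albino) for inhibition, with Rattus norvegicus as the target, read by paw edema, with stated times of 1 h and 4 h, at a dose of 40 mg/kg by the oral route; a lower number here means less inhibition, a higher number more inhibition at the dose given (going by the name of the read-out).
Compound 2 `Cc1nc(-c2ccccc2)sc1C1SCC(=O)N1c1ccc(F)c(Cl)c1` gives 28.6% in this assay.
Compound 3 `Cc1nc(Cc2ccc(Cl)cc2)sc1C1SCC(=O)N1c1ccccc1` is reported in this assay as "not active" (no number reported), without a number.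

Compound 1 and compound 2 share one core, and the change between them is chloro in place of hydrogen on an aromatic carbon. This change made the step of a number 36.5 percentage points higher from compound 2 to compound 1 (beyond the scatter). Compound 3 has a different core; the difference between the core of compound 3 and the core of compound 2 is not broken down here. Compound 4 `Cc1nc(Cc2ccc(Cl)cc2)sc1C1SCC(=O)N1c1ccc(Cl)cc1` has not yet been measured. It is separated from compound 3 by chloro in place of hydrogen on an aromatic carbon, the same change seen from compound 2 to compound 1, and this change occurs twice among these compounds. For the measured compounds named here, since compound 3 gave no number, no step can be computed to compound 4; the expectation rests only on the step from compound 2 to compound 1, which was large, and on the fact that compound 3 was reported inactive. A gain of roughly similar size from a low starting point would leave compound 4 modest. Compound 4 is therefore estimated at 35%, between 10% and 60%.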

Compound 4, a percentage reported as inhibition, in the whole organism at one dose (the size of the read-out at that dose, not a potency): 53.9%
Estimate against measurement, compound 4: 18.9 percentage points below; the range from low to high includes it.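

For the compounds shown here, compound 3 carries no number in this assay, so no step to compound 4, which gives 53.9% there, can be read. The compounds shown leave open how much of the activity of compound 4 goes with the 4-chlorophenyl group in place of the phenyl of compound 3. Nothing available here explains this result.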